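Diethylamino in place of hydroxy on a naphthoquinone spirohydantoin

The source may hold more compounds than are shown below. What is called first, only, known or untested is meant among the compounds shown, and "the series" means these compounds.

Compound 1 `O=C1C2=C(C(=O)c3ccccc31)C1(CS2)NC(=O)N(CCCO)C1=O` was assessed in a functional assay on SW-620 cells (Homo sapiens) for inhibition (a higher number here means a weaker inhibitor, a lower number a stronger inhibitor), where compound 1 gives 119 nM. For the measured compounds named here, that is the only number recorded for compound 1 in this assay, alongside one further entry that carries no single number. Compound 2 `NCCN1C(=O)NC2(CSC3=C2C(=O)c2ccccc2C3=O)C1=O` was measured three times in this assay; compound 2 gives 35 nM; 34 nM; 47 nM (3 entries), and these repeats, (the several entries of compound 2 in this assay, 35 nM; 34 nM; 47 nM (3 entries)), lie close together. No direct one-change step links compound 1 and compound 2, so only their two sets of values are shown side by side.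

Compound 3 `CCN(CC)CCCN1C(=O)NC2(CSC3=C2C(=O)c2ccccc2C3=O)C1=O` has not yet been measured. It differs from compound 1 by diethylamino in place of hydroxy on a saturated chain carbon, three bonds along the chain from an amide-type nitrogen in a ring. The change replaces the terminal hydroxy of the 3-hydroxypropyl chain with a diethylamino group, giving a 3-(diethylamino)propyl chain on the ring nitrogen.

Going by the values given here, since no measured step for this exact change exists, the expectation rests on compound 2, whose aminoethyl chain gives 35 nM; 34 nM; 47 nM (3 entries). Compound 3 is therefore expected to move downward, beyond the usual scatter, by about a 3.0-fold lower number from compound 1 to compound 3 (0.47 log units; beyond the scatter). Compound 3 is estimated at 40 nM, within a range from 15 nM to 120 nM.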

Compound 3, half-maximal inhibitory concentration: 54 nM
Beside the measured number, compound 3's estimate is 1.4-fold (0.13 log units) below it; the measured number falls inside the stated range.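

In this assay, replacing the terminal hydroxy of the 3-hydroxypropyl chain with diethylamino gives a 2.2-fold lower number from compound 1 to compound 3 (0.34 log units; beyond the scatter). For the compounds shown here, this is the first direct one-change reading at this place, on a saturated chain carbon, three bonds along the chain from an amide-type nitrogen in a ring, and it shows that the chain end accepts the larger diethylamino group, which has no hydrogen-bond donor, without losing inhibition. The step is modest, and the repeated entries of compound 2 show how closely values in this assay can agree: the several entries of compound 2 in this assay, 35 nM; 34 nM; 47 nM (3 entries)

Going by these compounds, a single step cannot separate the effect of the amine nitrogen from that of its two ethyl groups, so it remains open whether dimethylamino, pyrrolidine or a primary amine on the same propyl chain would read alike. On these data alone, it is also open whether a carboxylic acid at the chain end, or a longer chain such as 4-(diethylamino)butyl, would lower the number further or raise it again.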